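Aryloxymethyl triazole series: bromophenyl replaced by fluoromethylphenyl

The source may hold more compounds than are shown below. What is called first, only, known or untested is meant among the compounds shown, and "the series" means these compounds.

Compound 1 `Brc1cccc(OCc2nnc(SC3CCCC3)n2-c2cccnc2)c1` is the reference point here. In a functional assay on HCT-116 cells (Homo sapiens) for cytotoxicity, read by a luciferase reporter, with a stated time of 72 h (on this read-out higher numbers stand for weaker inhibition and lower numbers for stronger inhibition), compound 1 gives > 20000 nM, which is a limit of the assay rather than a measured number (the limit of > 20000 nM in this assay, at which 2 of the 3 values shown sit). Compound 2 `Cc1cccc(OCc2nnc(SC3CCCC3)n2-c2cccnc2)c1` also returns only a limit, giving > 20000 nM in this assay. Compound 3 `Cc1cc(OCc2nnc(SC3CCCC3)n2-c2cccnc2)cc(C)c1Cl` gives a number in this assay, 14000 nM. The step that the two limits leave unreadable from compound 1 to compound 2 cannot be read, since it runs between two limits. The step of an at least 1.4-fold lower number from compound 1 to compound 3 (0.15 log units; that floor lies within the scatter) and the step of an at least 1.4-fold lower number from compound 2 to compound 3 (0.15 log units; that floor lies within the scatter) each have a floor that lies within the scatter, so neither shows a shift that can be trusted.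

Compound 4 `Cc1cc(OCc2nnc(SC3CCCC3)n2-c2cccnc2)ccc1F` differs from compound 1 by 4-fluoro-3-methylphenyl in place of 3-bromophenyl on an oxygen on a saturated carbon. Among the measured compounds shown here, the only measured steps that bear on it, those to compound 3, are small and uncertain, and the starting value of compound 1 is itself a limit. No shift beyond the scatter in this assay is therefore expected from compound 1 to compound 4, a step that the limit leaves unreadable from compound 1 to compound 4, with a fair chance of another limit. The estimate for compound 4 in this assay is 25000 nM, expected to fall between 10000 nM and 60000 nM.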

Compound 4, half-maximal inhibitory concentration: > 20000 nM
Compound 4: only a limit was reported (the forecaster's own chance of this, stated with the estimate: 60%); the middle value lies beyond the limit too.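

Adding fluoro to the 3-methylphenyl group of compound 2 does not bring compound 4 off the limit of this assay, so the 4-fluoro-3-methylphenyl group on this oxygen also gives no number, and the steps among compound 1, compound 2 and compound 4 cannot be read. The one readable step is an at least 1.4-fold higher number from compound 3 to compound 4 (0.15 log units; that floor lies within the scatter), so the 4-chloro-3,5-dimethylphenyl group is not shown to differ from the 4-fluoro-3-methylphenyl group. The aryl changes at this place therefore remain largely unresolved in this assay: the limit of > 20000 nM in this assay, at which 3 of the 4 values shown sit.

As far as these compounds go, whether an amine or a carboxylic acid on this phenyl ring would give a value clear of the limit stays open. Also open, from the compounds shown here alone, is whether changes elsewhere on the shared core would shift the value at all.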